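A Pyrazole Replaces the Oxetane on the Amide Nitrogen

The source may hold more compounds than are shown below. What is called first, only, known or untested is meant among the compounds shown, and "the series" means these compounds.

Compound 1, `Cc1ccc(OCC(=O)N(Cc2cccs2)C2COC2)cc1`: 23000 nM
Compound 2, `CCN(Cc1cccs1)C(=O)COc1ccc(C(=O)O)cc1`: "not active" (no number reported)
Compound 3, `CCc1ccc(OCC(=O)N(CC)Cc2cccs2)cc1`: 67 nM

Of the compounds shown here, three have been tested in an assay on HEK293 cells for agonist activity at transient receptor potential cation channel subfamily M member 8 (Homo sapiens), read by fluorescence and calcium flux, with a stated time of 15 min; a higher number here means that more compound is needed for the effect, a lower number that less compound is needed. Compound 1 gives 23000 nM, the highest of the two numbers reported. The nearest number belongs to compound 3, which gives 67 nM in this assay, a gap that lies well beyond the scatter of repeated measurements. Compound 2 is recorded in this assay as "not active" (no number reported), without a number. Compound 1 and compound 3 differ in more than one place, so their two values are simply stated side by side.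

The unmeasured compound 4, `Cc1ccc(OCC(=O)N(Cc2cccs2)c2ccn(C)n2)cc1`, keeps the core of compound 1 and differs from it at a single position: 1-methyl-1H-pyrazol-3-yl in place of oxetan-3-yl on an amide-type nitrogen. Within the data shown here, no pair of measured compounds isolates this change, so its size in this assay is open. Given that compound 1 gives 23000 nM while compound 3 reaches 67 nM, the range of this series is wide, and compound 4 is expected to land at 6000 nM, between 1000 nM and 40000 nM. This estimate means a step of a 3.8-fold lower number from compound 1 to compound 4 (0.58 log units; beyond the scatter).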

Compound 4, half-maximal effective concentration: 855 nM
For compound 4 the middle estimate is 7.0-fold (0.85 log units) above the measured one; the measured number lies below the stated range.
By their numbers in this assay, from the lowest: compound 3; then compound 4; then compound 1.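

In this assay, exchanging oxetan-3-yl for 1-methyl-1H-pyrazol-3-yl on the amide-type nitrogen, whose other neighbours are the carbonyl carbon and a saturated chain carbon, gives a 27-fold lower number from compound 1 to compound 4 (1.43 log units; beyond the scatter). Among these compounds, this is the first comparison that isolates a single place: the earlier compounds showed only a wide spread of values, whereas this pair shows that a change at this one position is enough by itself to produce a large step. A five-membered aromatic ring with 2 hetero atoms is thus tolerated here in place of a four-membered non-aromatic ring, with the number falling rather than rising, but no available evidence accounts for the size of this step.

The compounds shown leave open which feature of the entering group matters, as ring size, aromatic character, the hetero atoms and the methyl group all change together in this one step. Also open, going by these compounds, is how a phenyl ring or a pyrazole without the methyl group on this nitrogen would compare with compound 4.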